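From a Cyclohexenyl Group to a Butyl Chain

The compounds below may be only part of what the source reports. "The series", "measured", "known", "first", "only" and "open" are said of these compounds alone.

Three measured compounds share one core. Compound 1 `COc1ccc(-c2cn(Cc3ccccc3)nn2)cc1` and compound 2 `Cc1ccc(-c2cn(Cc3ccccc3)nn2)cc1` are close relatives of compound 3 `C1=C(c2cn(Cc3ccccc3)nn2)CCCC1`. In a functional assay on KB cells (Homo sapiens) for antiproliferative activity, read by MTT assay, with a stated time of 72 h (on this read-out lower numbers stand for stronger inhibition and higher numbers for weaker inhibition), compound 1 gives 86600 nM and compound 2 gives 79500 nM; the step of a 1.1-fold lower number from compound 1 to compound 2 (0.04 log units; within the scatter) is within the scatter. Compound 3 stands only at a limit of the measurement, (the limit of > 100000 nM in this assay, at which 1 of the 3 values shown sits). In this assay compound 3 gives > 100000 nM, a limit rather than a number. Compound 4 `CCCCc1cn(Cc2ccccc2)nn1` differs from compound 3 by butyl in place of cyclohex-1-en-1-yl on an aromatic carbon. For the measured compounds named here, no measured step touches this change; the only measured step, a methyl for a methoxy, was small. Compound 4 is therefore expected near 120000 nM, between 50000 nM and 300000 nM, a step that the limit leaves unreadable from compound 3 to compound 4, quite possibly reported again only as a limit.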

Compound 4, half-maximal inhibitory concentration: > 100000 nM
Compound 4: a limit, no number; the forecaster's own chance of this, stated with the estimate: 60%; the middle value is on the limit's open side.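

In this assay, for the compounds shown here, compound 3 and compound 4 both give only a limit, so no step between them can be read. From the compounds shown here alone, whether cyclohex-1-en-1-yl or butyl gives stronger inhibition, and by how much, stays open.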